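Hydrazone aryl swap on a benzothiazole-bearing amide scaffold

This account rests on a few compounds, and the source may have more. Where it says the series, first, only, none or still open, it means among the compounds named here.

Measured so far:
compound 1 `O=C(N/N=C/c1cccnc1)c1ccc(-c2nc3ccccc3s2)cc1` — "not active" (no number reported)
compound 2 `COc1ccc(/C=N/NC(=O)c2ccc(-c3nc4ccccc4s3)cc2)c(O)c1` — 6970 nM
compound 3 `O=C(N/N=C/c1ccccc1O)c1ccc(-c2nc3ccccc3s2)cc1` — 5550 nM

In an assay on isolated protein for inhibition of Maltase-glucoamylase (Homo sapiens), with a stated time of 15 min (on this read-out higher numbers stand for weaker inhibition and lower numbers for stronger inhibition), compound 3 gives the lowest of the two numbers reported, and compound 2 stands closest to it with a 1.3-fold lower number from compound 2 to compound 3 (0.10 log units; within the scatter). Compound 1, which carries a pyridin-3-yl group at the same position, is reported as not active in this assay. Compound 4 `COc1cc(/C=N/NC(=O)c2ccc(-c3nc4ccccc4s3)cc2)cc(OC)c1` differs from compound 3 as follows: 3,5-dimethoxyphenyl in place of 2-hydroxyphenyl on a carbon with a double bond to nitrogen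

For the measured compounds named here, no measured step exchanges the 2-hydroxyphenyl group itself; the only step, from compound 2 to compound 3, removes a methoxy and is within the scatter. The change to compound 4 is larger than any step measured, so its size is uncertain. Compound 4 is expected to reach 9000 nM in this assay, between 4000 nM and 30000 nM, which means an expected 1.6-fold higher number from compound 3 to compound 4 (0.21 log units; within the scatter).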

Compound 4, half-maximal inhibitory concentration: 16200 nM
The estimate for compound 4 lay 1.8-fold (0.26 log units) below the measured number; low and high end bracket the measured number.
By their numbers in this assay, from the lowest: compounds 3 and 2 (each within the scatter of the next); then compound 4.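

For the compounds shown here, exchanging the aryl group on the carbon with a double bond to nitrogen gives a 2.9-fold higher number from compound 3 to compound 4 (0.47 log units; beyond the scatter) and a 2.3-fold higher number from compound 2 to compound 4 (0.37 log units; beyond the scatter) in this series, the first numbered steps here beyond the scatter. So this position does respond to the aryl group, although the one earlier numbered step, which only removed a methoxy, did not show it. No evidence is available that bears on this step. The compounds shown do not separate the loss of the hydroxy group from the gain of the two methoxy groups. As far as these compounds go, what an amine or a carboxylic acid on this aromatic ring would give remains open.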